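Aryl swap at the saturated ring carbon of the shared core

This account rests on a few compounds, and the source may have more. Where it says the series, first, only, none or still open, it means among the compounds named here.

Compound 3 (`Cc1cc(O)c(C2=NN(c3ccc(S(N)(=O)=O)cc3)C(/C=C/c3ccccc3)C2)cc1Cl`) gives 20200 nM in a functional assay on RXF 393 cells (Homo sapiens) for antiproliferative activity, with a stated time of 48 h (a higher number here means a weaker inhibitor of growth, a lower number a stronger inhibitor of growth), the highest of the three numbers. Compound 1 (`Cc1cc(O)c(C2=NN(c3ccc(S(N)(=O)=O)cc3)C(c3ccccc3O)C2)cc1Cl`) gives 13000 nM and compound 2 (`Cc1cc(O)c(C2=NN(c3ccc(S(N)(=O)=O)cc3)C(c3ccccc3Cl)C2)cc1Cl`) gives 8220 nM in this assay. The steps are a 1.6-fold higher number from compound 1 to compound 3 (0.19 log units; within the scatter) and a 2.5-fold higher number from compound 2 to compound 3 (0.39 log units; beyond the scatter). Compound 4 (`COc1ccc(C2CC(c3cc(Cl)c(C)cc3O)=NN2c2ccc(S(N)(=O)=O)cc2)cc1OC`) carries the change (3,4-dimethoxyphenyl in place of 2-phenylethenyl on a saturated ring carbon). Both measured steps that exchange the group on this saturated ring carbon bear on it: each aryl group gave a lower number than 2-phenylethenyl, one within the scatter and one modestly beyond it. A small downward step is therefore expected for compound 4, with the wider uncertainty of a group not yet seen here. The expected step is a 1.8-fold lower number from compound 3 to compound 4 (0.26 log units; within the scatter). Compound 4 is estimated at 11000 nM, within 4500 nM to 28000 nM.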

Compound 4, concentration for total growth inhibition: 7520 nM
For compound 4 the middle estimate is 1.5-fold (0.17 log units) above the measured one; low and high end bracket the measured number.
By their numbers in this assay, from the lowest: compounds 4, 2, 1 and 3 (each within the scatter of the next, the first and the last beyond it).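

The step to 3,4-dimethoxyphenyl at this saturated ring carbon is a 2.7-fold lower number from compound 3 to compound 4 (0.43 log units; beyond the scatter) in this assay and clears the scatter, as 2-chlorophenyl did against 2-phenylethenyl, while 2-hydroxyphenyl did not. Among the aryl groups no order appears: a 1.1-fold lower number from compound 2 to compound 4 (0.04 log units; within the scatter) and a 1.7-fold lower number from compound 1 to compound 4 (0.24 log units; within the scatter) both lie within the scatter. Adding two methoxy groups to the phenyl ring therefore gives a number that cannot be told apart from those of compound 1 and compound 2.

As far as these compounds go, whether a non-aromatic group on this carbon, such as an aminomethyl or a carboxylic acid, keeps the number in this range remains open. No measurement at hand explains these steps.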